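A few compounds are considered here, and "the series" means these few. Any claim that something is new, unique, unknown or untested is made for them only; others in the source may bear on it.

Of the compounds shown here, three have been measured in a functional assay on HL-60 cells (Homo sapiens) for cytotoxicity, read by MTT assay, with a stated time of 24 h; a higher number here means a weaker inhibitor, a lower number a stronger inhibitor. Compound 1 `COc1ccccc1N1CCN(CCCCCOc2c(Br)cc(Br)cc2Oc2ccc(Br)cc2Br)CC1` gives 32.2 ug/mL, and compound 3 `Brc1ccc(Oc2cc(Br)cc(Br)c2OCCCCCN2CCN(c3ccccc3)CC2)c(Br)c1` gives 41.6 ug/mL. Compound 2 `COc1c(Br)cc(Br)cc1Oc1ccc(Br)cc1Br` gives 28.2 ug/mL, the lowest of the three numbers, yet it stands within the scatter of both others. For the measured compounds named here, the only single-point step known, a 1.3-fold higher number from compound 1 to compound 3 (0.11 log units; within the scatter), also stays within the scatter. Compound 4 `CC(C)(C)C(=O)C(C#N)Oc1c(Br)cc(Br)cc1Oc1ccc(Br)cc1Br` has not been measured. It differs from compound 2 by cyano((tert-butyl)carbonyl)methyl in place of methyl on an oxygen on an aromatic ring. The step from compound 1 to compound 3 likewise altered a methoxy group without moving this assay beyond the scatter, so no step beyond the scatter is expected here either, in either direction. The estimate for compound 4 is 25 ug/mL, with a range from 10 ug/mL to 60 ug/mL, meaning an expected step of a 1.1-fold lower number from compound 2 to compound 4 (0.05 log units; within the scatter).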

Compound 4, half-maximal inhibitory concentration: 29.2 ug/mL
Estimate against measurement, compound 4: 1.2-fold (0.07 log units) below, within the range that was stated.
By their numbers in this assay, from the lowest: compounds 2, 4, 1 and 3 (each within the scatter of the next).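

In this assay, putting cyano((tert-butyl)carbonyl)methyl in place of methyl on this oxygen gives a 1.0-fold higher number from compound 2 to compound 4 (0.02 log units; within the scatter). This position on the shared core therefore accepts a much larger group, one carrying a carbonyl and a nitrile, with no step beyond the scatter. No measured finding is at hand to explain this result. As far as these compounds go, whether a carboxylic acid on a short chain at this oxygen, or a bare hydroxyl in place of the methoxy group, would move the number beyond the scatter remains open.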